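This account rests on a few compounds, and the source may have more. Where it says the series, first, only, none or still open, it means among the compounds named here.

Compound 1, with the structure `COc1cc(/C=N/N(C)c2nc3ccccc3s2)cc(OC)c1O`, was tested in a physicochemical assay on cells (Homo sapiens), with a stated time of 18 h, tested at 1 uM (a lower number here means a stronger effect, a higher number a weaker effect of the compound at the concentration tested), and gave 5%. Its close relative compound 3, with the structure `COc1cc(/C=N/N(C)c2nc3ccccc3s2)ccc1O`, gave 20% in this assay. Within the data shown here, the one change between them is hydrogen in place of methoxy on an aromatic carbon, and it produced a number 15 percentage points higher from compound 1 to compound 3 (beyond the scatter). The third measured compound, compound 2, has the structure `COc1cc(/C=N/N2C(=O)CSC2=S)cc(OC)c1O` and gave 59% in this assay, the highest of the three numbers; the difference between its core and the core of compound 1 is not broken down here, since the two differ by a large part of the molecule.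

Compound 4, with the structure `COc1cc(/C=N/N2C(=O)CSC2=S)ccc1O`, has not yet been measured. It differs from compound 2 by hydrogen in place of methoxy on an aromatic carbon. Among the measured compounds shown here, this is the same kind of change as the one from compound 1 to compound 3, though not the same: around the place of the change the earlier pair has the carbon meta to a large group, while in the present pair it is meta to a group of 9 heavy atoms. Since the cores differ, the earlier step is only a loose guide. For the measured compounds named here, the step expected from compound 2 to compound 4 in this assay is a number 11 percentage points higher from compound 2 to compound 4 (beyond the scatter), a rise of roughly the same order as the one seen from compound 1 to compound 3, because a number 15 percentage points higher from compound 1 to compound 3 (beyond the scatter) was observed there. Compound 4 is therefore estimated to give 70% in this assay, with an expected range from 52% to 88%.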

Compound 4, a percentage reported as activity, at one concentration (the size of the read-out at that concentration, not a potency): 66%
For compound 4 the middle estimate is 4 percentage points above the measured one, within the range that was stated.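

In this assay, among these compounds, hydrogen in place of methoxy on the core of compound 2 gave a number 7 percentage points higher from compound 2 to compound 4 (within the scatter), while the same kind of change on the core of compound 1 gave a number 15 percentage points higher from compound 1 to compound 3 (beyond the scatter), so only the step on the core of compound 1 is printed as beyond the scatter. The change therefore did not carry over as a step that can be told apart from the scatter, and the pair on the core of compound 2 shows no dependable effect of losing the methoxy group there; with a single pair on each core, however, this does not establish that the core sets the size of the step, nor that the change is without effect on the core of compound 2. Nothing given here bears on why the two steps read as they do.

On these data alone, all four compounds carry either methoxy or hydrogen at this aromatic carbon, so what an ethoxy group, a fluorine atom or an amine there would give on either core stays open. All four also keep the hydroxy group, which leaves open how a carboxylic acid in its place would read on either core.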